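Bromo in Place of Fluoro on the Amide Aryl Ring

This account rests on a few compounds, and the source may have more. Where it says the series, first, only, none or still open, it means among the compounds named here.

Compound 2 `O=C(Nc1cccc(-c2oc3cc(-c4ccc(F)cc4)ccc3c(=O)c2O)c1)c1ccc(F)cc1` was tested in a functional assay on A549 cells (Homo sapiens) for antiproliferative activity, read by CCK-8 assay, with a stated time of 72 h (a higher number here means a weaker inhibitor, a lower number a stronger inhibitor), and gave 6930 nM. Among the three measured compounds it holds the second highest number. Compound 1 `O=C(Nc1cccc(-c2oc3cc(-c4ccc(F)cc4)ccc3c(=O)c2O)c1)c1ccccc1F` gives 4410 nM, and the step of a 1.6-fold higher number from compound 1 to compound 2 (0.20 log units; within the scatter) lies within the scatter. Compound 3 `O=C(Nc1cccc(-c2oc3cc(-c4ccc(F)cc4)ccc3c(=O)c2O)c1)c1ccc(C(F)(F)F)cc1` gives 19400 nM, and the step of a 2.8-fold higher number from compound 2 to compound 3 (0.45 log units; beyond the scatter) lies beyond it, as does the step of a 4.4-fold higher number from compound 1 to compound 3 (0.64 log units; beyond the scatter).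

Compound 4 `O=C(Nc1cccc(-c2oc3cc(-c4ccc(F)cc4)ccc3c(=O)c2O)c1)c1ccc(Br)cc1` differs from compound 2 in one place: bromo in place of fluoro on an aromatic carbon. Among the measured compounds shown here, two measured steps bear on this change, both on the same aryl ring of the amide: the step of a 1.6-fold higher number from compound 1 to compound 2 (0.20 log units; within the scatter), which moved fluoro from one carbon to another and stayed within the scatter, and the step of a 2.8-fold higher number from compound 2 to compound 3 (0.45 log units; beyond the scatter), in which trifluoromethyl replaced fluoro and the number rose modestly. For the measured compounds named here, no measured compound carries a bromo, so the size of this step is not directly anchored. Because the step of a 2.8-fold higher number from compound 2 to compound 3 (0.45 log units; beyond the scatter) showed that a larger group at this carbon raised the number, a modest rise is expected for compound 4, with a real chance that it stays within the scatter. Compound 4 is therefore estimated at 10000 nM, with a range from 4000 nM to 25000 nM. The expected step is a 1.4-fold higher number from compound 2 to compound 4 (0.16 log units; within the scatter).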

Compound 4, half-maximal inhibitory concentration: 13500 nM
For compound 4 the middle estimate is 1.4-fold (0.13 log units) below the measured one, within the range that was stated.
By their numbers in this assay, from the lowest: compounds 1, 2, 4 and 3 (each within the scatter of the next, the first and the last beyond it).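

Within this assay, the exchange of fluoro for bromo, para to a large group, gives a 1.9-fold higher number from compound 2 to compound 4 (0.29 log units; within the scatter), so these two halogens are not separated at this carbon. The second comparison gives a 1.4-fold lower number from compound 3 to compound 4 (0.16 log units; within the scatter), so bromo is not separated from trifluoromethyl here either, even though the earlier step of a 2.8-fold higher number from compound 2 to compound 3 (0.45 log units; beyond the scatter) did separate trifluoromethyl from fluoro; compound 4 thus sits within the scatter of both, and the three groups do not fall into two clean classes. The 4-bromophenyl amide also joins the 4-(trifluoromethyl)phenyl amide in standing apart from the 2-fluorophenyl amide, with a 3.1-fold higher number from compound 1 to compound 4 (0.49 log units; beyond the scatter), whereas the 4-fluorophenyl amide did not.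

Nothing at hand explains why the numbers fall this way, and the trend across these three groups remains a description only. Open questions are whether chloro, methoxy or an amine at this carbon would stay in the same span, and whether bromo on the carbon that carries fluoro in compound 1 would give a lower number than bromo does in compound 4.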